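The source may report more compounds than this note shows. Statements on the series, on what has been measured and on what is new or still open speak of the compounds shown alone.

In an ADME assay on HepG2 2.2.15 cells (Homo sapiens) for cytotoxicity, read by MTT assay, with a stated time of 8 days (on this read-out higher numbers stand for lower toxicity in this test and lower numbers for higher toxicity in this test), compound 2 `CC(C)c1cc(-c2ccc(F)nc2F)nn(Cc2ccc(Cl)cc2)c1=O` gives 56700 nM, the highest of the two numbers in hand. Compound 3 `N#Cc1ccc(Cn2nc(-c3cc(Cl)c(NCCO)nc3F)c3ccccc3c2=O)cc1` gives 32100 nM, which lies within the scatter of compound 2. Compound 1 `N#Cc1ccc(Cn2nc(-c3cc(Cl)c(NCC(O)CO)nc3F)c3ccccc3c2=O)cc1` reaches only the assay limit, > 100000 nM. Within the data shown here, the single measured step, an at least 3.1-fold lower number from compound 1 to compound 3 (0.49 log units; beyond the scatter), sits on a different core and a saturated chain, so it does not bear on the change toward compound 4 `O=c1c(C2CC2)cc(-c2ccc(F)nc2F)nn1Cc1ccc(Cl)cc1`, which is cyclopropyl in place of isopropyl on an aromatic carbon. Among the measured compounds shown here, no measured step touches an isopropyl or a cyclopropyl, so no shift beyond the scatter is expected in this assay. Staying close to compound 2, compound 4 is expected at 50000 nM, within 20000 nM to 150000 nM. The step expected from this is a 1.1-fold lower number from compound 2 to compound 4 (0.05 log units; within the scatter), none beyond the scatter.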

Compound 4, half-maximal cytotoxic concentration: 39800 nM
Beside the measured number, compound 4's estimate is 1.3-fold (0.10 log units) above it; the measured number falls inside the stated range.
By their numbers in this assay, from the lowest: compounds 3, 4 and 2 (each within the scatter of the next). At a limit, above all of these: compound 1.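

Among these compounds, compound 2 and compound 4 form the first measured pair that differs at this position, the aromatic carbon opposite the ring nitrogen. In this assay, cyclopropyl in place of isopropyl gives a 1.4-fold lower number from compound 2 to compound 4 (0.15 log units; within the scatter), so exchanging these two groups of 3 carbon heavy atoms, one with a three-membered ring and one without, moves the number by no more than the scatter. Nothing on hand bears on the reason for this step.

Only these two carbon groups are shown at this position. From the compounds shown here alone, how an amine, a carboxylic acid or a longer chain there would read in this assay stays open.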